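A few compounds are considered here, and "the series" means these few. Any claim that something is new, unique, unknown or untested is made for them only; others in the source may bear on it.

Measured so far in a functional assay on MCF7 cells (Homo sapiens) for inhibition, read by MTT assay; a lower number here means a stronger inhibitor, a higher number a weaker inhibitor:
compound 1 `COc1cc2ncnc(Nc3ccc(NC(=O)c4cccc(C)c4)cc3)c2cc1OC`: 13000 nM
compound 2 `COc1cc2ncnc(Nc3ccc(NC(=O)c4ccc(C)cc4)cc3)c2cc1OC`: 19000 nM
compound 3 `CCc1ccc(C(=O)Nc2ccc(Nc3ncnc4cc(OC)c(OC)cc34)cc2)cc1`: 65000 nM

Compound 3 has the highest number of the three. The next structure is compound 4 `COc1cc2ncnc(Nc3ccc(NC(=O)c4ccc(C(C)(C)C)cc4)cc3)c2cc1OC`, with tert-butyl in place of ethyl on an aromatic carbon, para to a large group: tert-butyl in place of ethyl on an aromatic carbon.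

Among the measured compounds shown here, two measured steps bear on this change. The closest is a 3.4-fold higher number from compound 2 to compound 3 (0.53 log units; beyond the scatter), where 4-methylphenyl gives way to 4-ethylphenyl. The other is a 5.0-fold higher number from compound 1 to compound 3 (0.70 log units; beyond the scatter). For the measured compounds named here, by contrast, a 1.5-fold higher number from compound 1 to compound 2 (0.16 log units; within the scatter) says little, and no measured compound carries a tert-butyl, so the trend rests on very few points. Both relevant steps point upward, so a small further rise in this assay is expected, possibly none beyond the scatter. The expected move is a 1.4-fold higher number from compound 3 to compound 4 (0.14 log units; within the scatter). Compound 4 is estimated at 90000 nM, with an expected range of 30000 nM to 250000 nM.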

Compound 4, half-maximal inhibitory concentration: > 100000 nM
Compound 4: a limit, no number; the forecaster's own chance of this, stated with the estimate: 15%; at least 1.1-fold (0.04 log units) between middle value and limit.
By their numbers in this assay, from the lowest: compounds 1 and 2 (each within the scatter of the next); then compound 3. At a limit, above all of these: compound 4.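

Compound 4 reaches a limit rather than a number in this assay: the limit of > 100000 nM in this assay, at which 1 of the 4 values shown sits.

The step of an at least 1.5-fold higher number from compound 3 to compound 4 (0.18 log units; that floor lies within the scatter) has a floor that does not by itself separate tert-butyl from ethyl, whereas an at least 5.2-fold higher number from compound 2 to compound 4 (0.72 log units; beyond the scatter) and an at least 7.6-fold higher number from compound 1 to compound 4 (0.88 log units; beyond the scatter) clear the scatter. Methyl, ethyl and tert-butyl at this aromatic carbon now run in order of rising numbers through compound 2, compound 3 and compound 4, and no compound shown goes against that order, though its last member rests on a limit.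

Going by these compounds, how far compound 4 lies past its limit stays open. So does whether an amine, a carboxylic acid or a methoxy group at this aromatic carbon would give a lower number than the alkyl groups do.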